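Trimming a Substituted Phenyl Down to Plain Phenyl

A few compounds are considered here, and "the series" means these few. Any claim that something is new, unique, unknown or untested is made for them only; others in the source may bear on it.

Compound 3 `COc1cc(-c2nn(-c3cccc(NC(=O)c4ccc(Cl)c(C(F)(F)F)c4)c3)cc2-c2ccncc2)ccc1Cl` sits at a limit in a functional assay on SK-MEL-28 cells (Homo sapiens) for inhibition, read by sulforhodamine B assay, with a stated time of 48 h (on this read-out lower numbers stand for higher toxicity in this test and higher numbers for lower toxicity in this test), giving > 32500 nM; this is a limit of the test, not a number. Compound 1 `COc1cc(-c2nn(-c3cccc(NC(=O)Nc4ccc(Cl)c(Cl)c4)c3)cc2-c2ccncc2)ccc1Cl` also reaches only a limit, at > 50000 nM. Compound 2 `O=C(Nc1cccc(-n2cc(-c3ccncc3)c(-c3ccc(Cl)c(O)c3)n2)c1)Nc1ccc(Cl)c(Cl)c1` likewise stops at a limit, > 32500 nM. Two of the three values rest at one ceiling the limit of > 32500 nM in this assay, at which 2 of the 3 values shown sit, and the remaining one at a higher ceiling (the limit of > 50000 nM in this assay, at which 1 of the 3 values shown sits).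

Compound 4 `COc1cc(-c2nn(-c3cccc(NC(=O)c4ccccc4)c3)cc2-c2ccncc2)ccc1Cl` differs from compound 3 by phenyl in place of 4-chloro-3-(trifluoromethyl)phenyl on a carbonyl carbon. Among the compounds with values here, the only measured step that touches the same carbonyl-bound group is a step that the two limits leave unreadable from compound 1 to compound 3, so its size cannot be read, and the same holds for a step that the two limits leave unreadable from compound 1 to compound 2. Within the data shown here, no measured step therefore gives a direction for compound 4 in this assay. Because all three neighbours rest at a ceiling (the limit of > 32500 nM in this assay, at which 2 of the 3 values shown sit), the expectation is that compound 4 stays there too, with a step that the limit leaves unreadable from compound 3 to compound 4 expected to be small. Compound 4 is therefore estimated at 40000 nM, within a range from 15000 nM to 100000 nM.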

Compound 4, concentration lethal to 50% of the cells: > 100000 nM
Compound 4: no number, only a limit (the forecaster's own chance of this, stated with the estimate: 80%); middle value at least 2.5-fold (0.39 log units) away from the limit.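

Compound 4 also reaches only a limit, > 100000 nM. The steps to compound 4 from compound 3 and from compound 1 therefore cannot be read. The compounds shown leave open how much any of these changes alters toxicity in this assay, as none of them has an actual number.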